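From 2-cyanocyclopropyl to 3-cyanocyclobutyl on a shared core

The source may hold more compounds than are shown below. What is called first, only, known or untested is meant among the compounds shown, and "the series" means these compounds.

Three compounds have been measured so far in an ADME assay on MDCKII-LE cells (Canis lupus familiaris) for permeability (a higher number here means that the compound crosses the layer faster, a lower number that the compound crosses the layer more slowly), and give these numbers:
- Compound 1 `NC(=O)[C@@H](CCC(F)(F)F)N(CC12CC(c3ncon3)(C1)C2)S(=O)(=O)c1ccc(Cl)cc1` gives 19.3 10^-6 cm/s
- Compound 2 `N#CCCCCN([C@H](CCC(F)(F)F)C(N)=O)S(=O)(=O)c1ccc(Cl)cc1` gives 24 10^-6 cm/s
- Compound 3 `N#C[C@H]1C[C@@H]1CN([C@H](CCC(F)(F)F)C(N)=O)S(=O)(=O)c1ccc(Cl)cc1` gives 21.5 10^-6 cm/s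

Compound 3 at 21.5 10^-6 cm/s lies within the scatter of both compound 1 and compound 2, so repeat measurements alone could reshuffle these three and no real ranking can be drawn.

The next compound is compound 4 `N#C[C@H]1C[C@H](CN([C@H](CCC(F)(F)F)C(N)=O)S(=O)(=O)c2ccc(Cl)cc2)C1` and it differs from compound 3 in one place: 3-cyanocyclobutyl in place of 2-cyanocyclopropyl on a saturated chain carbon bound to a sulfonamide nitrogen. In words, 3-cyanocyclobutyl stands in place of 2-cyanocyclopropyl on a saturated chain carbon bound to a sulfonamide nitrogen.

For the measured compounds named here, the closest precedent is a change of group at that same place, a 1.1-fold lower number from compound 2 to compound 3 (0.05 log units; within the scatter). Two wider swaps there, a 1.2-fold higher number from compound 1 to compound 2 (0.09 log units; within the scatter) and a 1.1-fold higher number from compound 1 to compound 3 (0.05 log units; within the scatter), also stayed small. None of the three compounds goes against this picture, though three compounds are a thin basis and none of them carries the new ring.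

No step beyond the scatter is therefore expected in this assay, and the estimated change is a 1.0-fold lower number from compound 3 to compound 4 (0.01 log units; within the scatter) as a best guess. For compound 4 the expected value is 21 10^-6 cm/s with an estimated range from 13 10^-6 cm/s to 33 10^-6 cm/s around it.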

Compound 4, apparent permeability: 24.9 10^-6 cm/s
Compound 4: middle estimate off by 1.2-fold (0.07 log units), on the low side; measured number inside the range.
By their numbers in this assay, from the lowest: compounds 1, 3, 2 and 4 (each within the scatter of the next).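

Replacing the three-membered ring of 2-cyanocyclopropyl with the four-membered ring of 3-cyanocyclobutyl, on a saturated chain carbon bound to a sulfonamide nitrogen, gives a step within the scatter in this assay (a 1.2-fold higher number from compound 3 to compound 4 (0.06 log units; within the scatter)). The new ring also reads like the open chain of 3-cyanopropyl (a 1.0-fold higher number from compound 2 to compound 4 (0.02 log units; within the scatter)) and like the much larger group of compound 1 (a 1.3-fold higher number from compound 1 to compound 4 (0.11 log units; within the scatter)), so this position now tolerates a three-membered ring, a four-membered ring, an open chain and a larger group with two ring types, without any of the four compounds going against that flat picture. Nothing available explains why these groups read alike.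

The compounds shown leave open whether a group of another kind at this place, such as an amine or a carboxylic acid, would give a step beyond the scatter in this assay. They also leave open whether a change elsewhere on the shared core, which is the same in all four compounds, would matter more than any change at this position.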